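The source may report more compounds than this note shows. Statements on the series, on what has been measured and on what is new or still open speak of the compounds shown alone.

Working notes on the acylurea–hydrazone series.

Three compounds have been run in a functional assay on A549 cells (Homo sapiens) for inhibition, read by MTT assay, with a stated time of 72 h; on this read-out higher numbers stand for weaker inhibition and lower numbers for stronger inhibition. Compound 2 `Cc1nc(N(C)C(=O)NC(=O)c2c(F)cccc2F)sc1C(=O)N/N=C/c1ccccc1C(F)(F)F` gives 5.43 ug/mL in this assay, the lowest of the three numbers. Compound 3 `CN(C(=O)NC(=O)c1c(F)cccc1F)c1nc(C(F)(F)F)c(C(=O)N/N=C/c2ccccc2C(F)(F)F)s1` gives 17.9 ug/mL in this assay, and the single-point step, trifluoromethyl in place of methyl on an aromatic carbon, reads a 3.3-fold higher number from compound 2 to compound 3 (0.52 log units; beyond the scatter). Compound 1 `Cc1nc(N(C)C(=O)NC(=O)c2ccc(Cl)cc2Cl)sc1C(=O)N/N=C/c1ccc(C(F)(F)F)cc1` gives 30.2 ug/mL in this assay; it differs from compound 2 in two places, so its gap to compound 2 is noted only as the two values show it.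

Compound 4 `Cc1nc(N(C)C(=O)NC(=O)c2c(F)cccc2F)sc1C(=O)N/N=C/c1ccc(C(F)(F)F)cc1` is the next entry. Relative to compound 2 the change is 4-(trifluoromethyl)phenyl in place of 2-(trifluoromethyl)phenyl on a carbon with a double bond to nitrogen. Among the measured compounds shown here, no measured step isolates this move, since the only single-point step available, from compound 2 to compound 3, concerns the core and not the hydrazone aryl ring. For the measured compounds named here, compound 1, the one measured compound carrying 4-(trifluoromethyl)phenyl on that carbon, shows the highest number of the three, but it also carries a different acyl group, so it cannot be read as a clean precedent.

With no direct guide, the expected step for compound 4 in this assay is a 2.2-fold higher number from compound 2 to compound 4 (0.34 log units; beyond the scatter), leaning toward a higher number. Compound 4 is therefore estimated at 12 ug/mL in this assay, within 4 ug/mL to 35 ug/mL.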

Compound 4, half-maximal inhibitory concentration: 60.5 ug/mL
Estimate against measurement, compound 4: 5.0-fold (0.70 log units) below; the whole stated range lies below it.
By their numbers in this assay, from the lowest: compound 2; then compounds 3, 1 and 4 (each within the scatter of the next, the first and the last beyond it).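

In this assay, 4-(trifluoromethyl)phenyl in place of 2-(trifluoromethyl)phenyl on a carbon with a double bond to nitrogen gives an 11-fold higher number from compound 2 to compound 4 (1.05 log units; beyond the scatter), a large step from moving one group while the atoms of the two compounds stay the same, so this carbon's aryl group is sensitive to where the trifluoromethyl sits, at least with the 2,6-difluorophenyl acyl group. With 4-(trifluoromethyl)phenyl held constant, 2,6-difluorophenyl in place of 2,4-dichlorophenyl on a carbonyl carbon reads a 2.0-fold higher number from compound 1 to compound 4 (0.30 log units; within the scatter), so compound 1 and compound 4 are not separated by this assay and the acyl change shows no resolved effect in this pair. No measurement available here accounts for the step at this position.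

Still open, going by these compounds, is whether 2-(trifluoromethyl)phenyl on this carbon would bring a comparable step with the 2,4-dichlorophenyl acyl group or on the trifluoromethyl-bearing core of compound 3. Also open, on these data alone, is how an unsubstituted phenyl, or a phenyl carrying a nitrile or a methoxy group instead of trifluoromethyl, would read on the same carbon.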